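The source may hold more compounds than are shown below. What is called first, only, known or untested is meant among the compounds shown, and "the series" means these compounds.

Measured so far in a functional assay on Hs 683 cells (Homo sapiens) for inhibition, read by colorimetric assay and MTT assay, with a stated time of 72 h; a higher number here means a weaker inhibitor, a lower number a stronger inhibitor:

Compound 1, `COc1cc(C(=O)NNC(=S)Nc2csc(-c3ccccc3)c2)cc(OC)c1OC`, gives 42000 nM.
Compound 2, `COc1cc(C(=O)NNC(=S)Nc2csc(-c3ccc(C)cc3)c2)cc(OC)c1OC`, gives 42000 nM.
Compound 3, `COc1ccc(C(=O)NNC(=S)Nc2csc(-c3ccccc3)c2)cc1`, gives 35000 nM.

Compound 4, `COc1ccc(C(=O)NNC(=S)Nc2csc(-c3ccc(C)cc3)c2)cc1`, has not yet been measured in this assay.

Compound 2 differs from compound 1 by methyl in place of hydrogen on an aromatic carbon. That change made no change at the digits printed from compound 1 to compound 2 (within the scatter). Compound 4 differs from compound 3 by methyl in place of hydrogen on an aromatic carbon. The two place lines agree word for word, so this is the same change made on a different core. How the core of compound 3 differs from the core of compound 1 is not broken down here; what the two values show is that compound 3 and compound 1 lie within the scatter of each other in this assay, and the same holds for compound 3 against compound 2. Among the compounds with values here, no compound among the three measured can be called stronger or weaker than another on these numbers.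

Within the data shown here, the only measured step of this kind was flat. The expectation for compound 4 therefore rests on the step of no change at the digits printed from compound 1 to compound 2 (within the scatter) and on the value of compound 3, 35000 nM, and the step from compound 3 to compound 4 is expected to be a 1.0-fold higher number from compound 3 to compound 4 (0.01 log units; within the scatter). Compound 4 is expected to give 36000 nM in this assay, with a likely range from 20000 nM to 65000 nM. Among the measured compounds shown here, the range is set wide because the single comparable step no change at the digits printed from compound 1 to compound 2 (within the scatter) is one observation only, and weak inhibitors near this level are sometimes reported as a limit rather than a number.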

Compound 4, half-maximal inhibitory concentration: 12000 nM
For compound 4 the middle estimate is 3.0-fold (0.48 log units) above the measured one; measured number outside the range, below it.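

In this assay, phenyl to 4-methylphenyl gives a 2.9-fold lower number from compound 3 to compound 4 (0.46 log units; beyond the scatter), a modest step. The change therefore does not carry over at a fixed size between these two cores, as the comparison of the two steps shows: the same change on two cores in this assay, no change at the digits printed (within the scatter) from compound 1 to compound 2 and a 2.9-fold lower number (0.46 log units; beyond the scatter) from compound 3 to compound 4, 2.9-fold (0.46 log units) apart, beyond the scatter of two such steps. Within the data shown here, this rests on only two pairs, so it shows that the size of the step differs with the core here, but not which difference between the cores goes with that, nor what the same change would do on any further core, and it gives no rule for the series.

The compounds shown leave open whether the lower number on the second core is particular to methyl, or whether an ethyl group, a chlorine atom, an amine or a carboxylic acid in the same place, para to a large group, would give a similar step on either core. Also open, on these data alone, is whether the difference between the two steps would appear in any cell line other than the one used in this assay.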